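Swapping the fluorinated ring on a cyano compound

The source may report more compounds than this note shows. Statements on the series, on what has been measured and on what is new or still open speak of the compounds shown alone.

Compound 1 `COc1ccc(/C=C2\CN(C)C/C(=C\c3ccccc3F)C2=O)cc1` gives 18400 nM
Compound 2 `CN1C/C(=C\c2ccc(C(C)(C)C)cc2)C(=O)/C(=C/c2ccccc2F)C1` gives 18200 nM
Compound 3 `CN1C/C(=C\c2ccc(C#N)cc2)C(=O)/C(=C/c2ccccc2F)C1` gives 2670 nM

In a functional assay on K562 cells (Homo sapiens) for cytotoxicity, read by MTT assay, with a stated time of 24 h (on this read-out higher numbers stand for weaker inhibition and lower numbers for stronger inhibition), compound 3 stands lowest of the three, and its gaps to compound 1 and compound 2 both lie beyond the scatter. Compound 4 `CN1C/C(=C\c2ccc(Br)cc2)C(=O)/C(=C/c2ccc(C#N)cc2)C1` has not been measured. Its difference from compound 3 is 4-bromophenyl in place of 2-fluorophenyl on a double-bonded chain carbon bound to a double-bonded ring carbon with 4-bromophenyl in place of 2-fluorophenyl on a double-bonded chain carbon bound to a double-bonded ring carbon. Among the compounds with values here, all three measured compounds carry the 2-fluorophenyl group, so no measured step tests this swap directly. The nearest guide comes from changes at the other aromatic group. One change made no real difference (a 1.0-fold lower number from compound 1 to compound 2 (0.00 log units; within the scatter)), while two were modest (a 6.9-fold lower number from compound 1 to compound 3 (0.84 log units; beyond the scatter) and a 6.8-fold lower number from compound 2 to compound 3 (0.83 log units; beyond the scatter)). Those steps suggest how far one aromatic substituent change can move the number, but not which way this swap will go. The expected change is small, with no direction favoured (a 1.1-fold higher number from compound 3 to compound 4 (0.05 log units; within the scatter)). The estimated value for compound 4 is 3000 nM with an expected range of 700 nM to 12000 nM on this read-out.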

Compound 4, half-maximal inhibitory concentration: 7420 nM
Estimate against measurement, compound 4: 2.5-fold (0.39 log units) below; low and high end bracket the measured number.
By their numbers in this assay, from the lowest: compound 3; then compound 4; then compounds 2 and 1 (each within the scatter of the next).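

The carbon carrying the 2-fluorophenyl group now has its first measured change: in this assay the swap to 4-bromophenyl, with the cyano-bearing aromatic ring kept, gives a 2.8-fold higher number from compound 3 to compound 4 (0.44 log units; beyond the scatter) on this read-out. Within the data shown here, the number therefore responds to a change at this aromatic group, whereas the earlier steps showed only changes at the other one. No measurement shown here accounts for the shift.

The swap alters both the halogen and its numbered ring position, so a 2-bromophenyl or 4-fluorophenyl group at this carbon would be needed to tell the two changes apart. Also open, on these data alone, is how a phenyl ring carrying an amine or a carboxylic acid would behave here, and whether this swap gives a similar step when methoxy or tert-butyl replaces the cyano group.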